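The compounds below may be only part of what the source reports. "The series", "measured", "known", "first", "only" and "open" are said of these compounds alone.

Two compounds sharing one core have been examined in a functional assay on SK-BR-3 cells (Homo sapiens) for antiproliferative activity, read by MTT assay, with a stated time of 72 h; a higher number here means a weaker inhibitor, a lower number a stronger inhibitor. Compound 1, with the structure `C/C=C1/[C@H](O[C@@H]2O[C@H](CO)[C@@H](O)[C@H](O)[C@H]2O)OC=C(C(=O)OC)[C@H]1CC(=O)OCCc1ccc2c(c1)OCCO2`, gives in this assay a reading of > 20000 nM, and this is a limit of the assay rather than a number. Compound 2, with the structure `C/C=C1/[C@H](O[C@@H]2O[C@H](COC(C)=O)[C@@H](OC(C)=O)[C@H](OC(C)=O)[C@H]2OC(C)=O)OC=C(C(=O)OC)[C@H]1CC(=O)OCCC(C)C`, likewise gives in this assay only a limit, > 15000 nM. Compound 1 thus stands at one of the two limits shown, namely (the limit of > 20000 nM in this assay, at which 1 of the 2 values shown sits). The other compound sits at the other limit, (the limit of > 15000 nM in this assay, at which 1 of the 2 values shown sits). Going by the values given here, since neither reading is a number, no step between the measured compounds can be sized, and no trend can be drawn from them.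

Compound 3, with the structure `C/C=C1/[C@H](O[C@@H]2O[C@H](CO)[C@@H](O)[C@H](O)[C@H]2O)OC=C(C(=O)OC)[C@H]1CC(=O)OCCc1ccc(O)c(O)c1`, differs from compound 1 in a single place: 3,4-dihydroxyphenyl in place of 2,3-dihydro-1,4-benzodioxin-6-yl on a saturated chain carbon, two bonds along the chain from an oxygen next to a carbonyl group. Among the compounds with values here, nothing among the measured compounds shows how this change moves activity, so the step from compound 1 to compound 3 is expected to be small, no more than the scatter. Compound 3 is accordingly expected to give in this assay about 20000 nM, within a range from 7000 nM to 60000 nM, and most likely only a limit again. The expected step of a number no higher from compound 1 to compound 3 (the limit leaves the size open) is estimated to lie within the scatter.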

Compound 3, half-maximal inhibitory concentration: 160000 nM
The estimate for compound 3 lay 8.0-fold (0.90 log units) below the measured number; the measured number lies above the stated range.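

In this assay compound 3 gives 160000 nM as a true number. Going by these compounds alone, no step from compound 1 to compound 3 can be read, because compound 1 gives only a limit and not a number: the limit of > 20000 nM in this assay, at which 1 of the 3 values shown sits. From the compounds shown here alone, what stays open is how far, and even whether, 3,4-dihydroxyphenyl in place of 2,3-dihydro-1,4-benzodioxin-6-yl moves activity.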